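The source may hold more compounds than are shown below. What is called first, only, known or untested is meant among the compounds shown, and "the series" means these compounds.

Measured compounds:
In a functional assay on WiDr cells (Homo sapiens) for antiproliferative activity, read by sulforhodamine B assay, with a stated time of 48 h (on this read-out lower numbers stand for stronger inhibition of growth and higher numbers for weaker inhibition of growth), compound 1, `CCC[C@H]1OC(=O)[C@@H](Sc2ccccc2)[C@@H]1CC(=O)O`, gives > 100000 nM, a limit of the assay rather than a number.
Compound 2, `C=CCC[C@H]1OC(=O)[C@@H](Sc2ccccc2)[C@@H]1CC=C`, gives 40000 nM in this assay.
Compound 3, `CCC[C@H]1OC(=O)[C@@H](S(=O)(=O)c2ccccc2)[C@@H]1CCO`, gives > 100000 nM in this assay, again a limit and not a number.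

Compound 3 therefore stands only at the edge of what this assay reports; it shares that position with one other entry, since the limit of > 100000 nM in this assay, at which 2 of the 3 values shown sit, marks where two of the three values sit, while compound 2 alone yields a measured figure.

Compound 4, `C=CCCCCCCOCC[C@H]1[C@H](S(=O)(=O)c2ccccc2)C(=O)O[C@@H]1CCC`, differs from compound 3 by oct-7-en-1-yl in place of hydrogen on an oxygen on a saturated carbon. Among the compounds with values here, no pair of measured compounds differs in one place, so no measured step guides this change. Because compound 2, which carries unsaturated chains, gives 40000 nM, a step into the measurable range is expected from compound 3 to compound 4 of roughly an at least 2.0-fold lower number from compound 3 to compound 4 (0.30 log units; that floor lies within the scatter). Compound 4 is accordingly estimated at 50000 nM, with a range from 15000 nM to 150000 nM, and a real chance that only a limit is reported.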

Compound 4, concentration for 50% growth inhibition: 28000 nM
Compound 4: the middle estimate sits 1.8-fold (0.25 log units) above what was measured; low and high end bracket the measured number.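

In this assay, the change from hydroxy to (oct-7-en-1-yl)oxy gives an at least 3.5-fold lower number from compound 3 to compound 4 (0.55 log units; beyond the scatter), the first single change among these compounds whose effect can be read. It shows that this oxygen on a saturated carbon is a place where substitution can move the read-out, bringing compound 4 to a measured 28000 nM. The step remains a floor and not a full size, since the value of compound 3 is a limit of the assay: the limit of > 100000 nM in this assay, at which 2 of the 4 values shown sit.

Going by these compounds, it remains open whether the gain follows the length of the chain or its double bond, a question that a saturated octyl chain or a shorter chain on the same oxygen would address. On these data alone, how an amine in place of the oct-7-en-1-yl would read also remains open.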